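Extending the Hydroxyalkoxy Chain of Compound 2

The source may report more compounds than this note shows. Statements on the series, on what has been measured and on what is new or still open speak of the compounds shown alone.

Compound 1, `COC(=O)COc1cc(CNc2nc3c(N)ncnc3n2[C@@H]2O[C@H](CO)[C@@H](O)[C@H]2O)ccc1-c1ccccc1`, in an assay on COS-7 cells for inhibition of sodium/nucleoside cotransporter 2 (Homo sapiens), read by scintillation counting (a lower number here means a stronger inhibitor, a higher number a weaker inhibitor), gives 3300 nM.
Compound 2, `Nc1ncnc2c1nc(NCc1ccc(-c3ccccc3)c(OCCO)c1)n2[C@@H]1O[C@H](CO)[C@@H](O)[C@H]1O`, in this assay gives 3100 nM.

Compound 2 stands alongside compound 1, as the step of a 1.1-fold lower number from compound 1 to compound 2 (0.03 log units; within the scatter) shows; the two are not distinguished. Compound 3, `Nc1ncnc2c1nc(NCc1ccc(-c3ccccc3)c(OCCCCO)c1)n2[C@@H]1O[C@H](CO)[C@@H](O)[C@H]1O`, differs from compound 2 by 2-hydroxyethyl in place of hydroxy on a saturated chain carbon, two bonds along the chain from an oxygen on an aromatic ring. For the measured compounds named here, the single measured step, a 1.1-fold lower number from compound 1 to compound 2 (0.03 log units; within the scatter), concerns a different change and stayed within the scatter, so no measured step bears directly on this chain extension. The step of a 1.0-fold lower number from compound 2 to compound 3 (0.01 log units; within the scatter) is therefore expected to lie within the scatter. The estimate for compound 3 is 3000 nM, in the range 1000 nM to 9000 nM.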

Compound 3, half-maximal inhibitory concentration: 940 nM
The estimate for compound 3 lay 3.2-fold (0.50 log units) above the measured number; measured number outside the range, below it.
By their numbers in this assay, from the lowest: compound 3; then compounds 2 and 1 (each within the scatter of the next).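

In this assay, for the compounds shown here, the 2-hydroxyethoxy to 4-hydroxybutoxy change gives the first step beyond the scatter (a 3.3-fold lower number from compound 2 to compound 3 (0.52 log units; beyond the scatter)), a modest one. The earlier change at this chain, from methoxycarbonyl to hydroxymethyl, had stayed within the scatter, and the comparison with the ester shows a similar modest step (a 3.5-fold lower number from compound 1 to compound 3 (0.55 log units; beyond the scatter)), so among these compounds the length of the hydroxy-ended chain moves the number. Nothing measured here explains the drop.
As far as these compounds go, whether a longer chain would lower the number further remains open. So does whether an amine or a carboxylic acid at the chain end would serve as well as the hydroxy.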